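What happens when compound 3 loses its bromines?

The compounds below may be only part of what the source reports. "The series", "measured", "known", "first", "only" and "open" are said of these compounds alone.

Measured so far in a functional assay on HepG2 cells (Homo sapiens) for cytotoxicity, read by MTT assay, with a stated time of 72 h; a higher number here means a weaker inhibitor, a lower number a stronger inhibitor
compound 1 `O=C(N/N=C/c1cccc(Br)c1)Nc1cc2c(Nc3ccc(F)c(Cl)c3)ncnc2cc1O[C@H]1CCOC1` gives 32300 nM
compound 2 `N#Cc1ccc(/C=N/NC(=O)Nc2cc3c(Nc4ccc(F)c(Cl)c4)ncnc3cc2O[C@H]2CCOC2)cc1` gives 26400 nM
compound 3 `O=C(N/N=C/c1cc(Br)c(O)c(Br)c1)Nc1cc2c(Nc3ccc(F)c(Cl)c3)ncnc2cc1O[C@H]1CCOC1` gives 2740 nM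

Compound 3 has the lowest number of the three, and its steps to both others lie beyond the scatter. Compound 4 `O=C(N/N=C/c1ccc(O)cc1O)Nc1cc2c(Nc3ccc(F)c(Cl)c3)ncnc2cc1O[C@H]1CCOC1` differs from it by 2,4-dihydroxyphenyl in place of 3,5-dibromo-4-hydroxyphenyl on a carbon with a double bond to nitrogen and has 2,4-dihydroxyphenyl in place of 3,5-dibromo-4-hydroxyphenyl on a carbon with a double bond to nitrogen. Putting in 3,5-dibromo-4-hydroxyphenyl gave a 12-fold lower number from compound 1 to compound 3 (1.07 log units; beyond the scatter) and a 9.6-fold lower number from compound 2 to compound 3 (0.98 log units; beyond the scatter) and both lie beyond the scatter. By contrast, a 1.2-fold lower number from compound 1 to compound 2 (0.09 log units; within the scatter) stays within it. Among the compounds with values here, no measured compound carries 2,4-dihydroxyphenyl, so this is uncertain. A partial move back towards the higher numbers is expected, with a 3.3-fold higher number from compound 3 to compound 4 (0.52 log units; beyond the scatter) as the estimated step. The estimate for compound 4 is 9000 nM (range 2500 nM to 32000 nM).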

Compound 4, half-maximal inhibitory concentration: 4530 nM
Estimate against measurement, compound 4: 2.0-fold (0.30 log units) above, and the stated range covers the measured number.
By their numbers in this assay, from the lowest: compounds 3 and 4 (each within the scatter of the next); then compounds 2 and 1 (each within the scatter of the next).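

In this assay, bromine proves unnecessary for the low number at this position: a 1.7-fold higher number from compound 3 to compound 4 (0.22 log units; within the scatter) and 2,4-dihydroxyphenyl carries none. The two hydroxyl-bearing rings also stand apart from the two without hydroxyl, with a 5.8-fold lower number from compound 2 to compound 4 (0.77 log units; beyond the scatter) and a 7.1-fold lower number from compound 1 to compound 4 (0.85 log units; beyond the scatter) and no listed compound going against this split. Nothing available explains this difference.

The compounds shown leave open whether hydroxyl itself is what counts. They also leave open whether an amine or a carboxylic acid on the phenyl ring would give a similar number.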